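This account rests on a few compounds, and the source may have more. Where it says the series, first, only, none or still open, it means among the compounds named here.

- compound 1 `CCc1ccc(-c2nc3c(c(C)nn3-c3ccccc3)c(-c3ccccc3OC)c2C#N)cc1` gives 7800 nM
- compound 2 `CCc1ccc(-c2nc3c(c(C)nn3-c3ccccc3)c(-c3ccccc3OC(F)(F)F)c2C#N)cc1` gives 9900 nM

In a physicochemical assay for solubility, read by spectrophotometry, in phosphate buffer, with a stated time of 18 h, at pH 7.4 (on this read-out higher numbers stand for higher solubility and lower numbers for lower solubility), compound 2 gives 9900 nM and lies within the scatter of compound 1, so neither ranks above the other. Compound 3 `CCc1ccc(-c2nc3c(c(C)nn3-c3ccccc3)c(-c3ccccc3)c2C#N)cc1` has hydrogen in place of trifluoromethoxy on an aromatic carbon, ortho to a large group hydrogen in place of trifluoromethoxy on an aromatic carbon and so 2-(trifluoromethoxy)phenyl becomes phenyl. For the measured compounds named here, the only measured step, a 1.3-fold higher number from compound 1 to compound 2 (0.10 log units; within the scatter), alters the group on the oxygen but keeps that oxygen in place. Going by the values given here, no measured compound lacks the substituent, so this small step offers only indirect guidance, and no change beyond the scatter is expected. The expected change is a 1.2-fold lower number from compound 2 to compound 3 (0.09 log units; within the scatter) in this assay and no direction is firmly supported. For compound 3 the estimated value is 8000 nM, with an expected range from 3500 nM to 16000 nM.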

Compound 3, solubility: 47000 nM
Compound 3: the middle estimate sits 5.9-fold (0.77 log units) below what was measured, outside the stated range (above it).
By their numbers in this assay, from the lowest: compounds 1 and 2 (each within the scatter of the next); then compound 3.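

In this assay the step of a 4.7-fold higher number from compound 2 to compound 3 (0.68 log units; beyond the scatter) and the step of a 6.0-fold higher number from compound 1 to compound 3 (0.78 log units; beyond the scatter) both lie beyond the scatter, whereas the change on the oxygen, a 1.3-fold higher number from compound 1 to compound 2 (0.10 log units; within the scatter), does not. Among these three compounds, then, what separates the numbers at this aromatic carbon, ortho to a large group, is whether the oxygen-linked substituent is present or replaced by hydrogen, not whether it is methoxy or trifluoromethoxy. Nothing available explains why hydrogen at this carbon goes with the higher number.

The compounds shown leave open whether any substituent here goes with the lower numbers or only those joined through oxygen, which a methyl, a chlorine or an amine at this carbon would help settle. They also leave open whether this change reads the same on any core other than this one.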